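The source may report more compounds than this note shows. Statements on the series, on what has been measured and on what is new or still open speak of the compounds shown alone.

Measured in a functional assay on MCF7 cells (Homo sapiens) for antiproliferative activity, read by MTT assay, with stated times of 24 h and 72 h; on this read-out lower numbers stand for stronger inhibition and higher numbers for weaker inhibition:
- compound 1 (`COc1ccc([C@@H]2[C@H](Oc3ccccc3)C(=O)N2c2cc(OC)c(OC)c(OC)c2)cc1OC`) gives 26000 nM
- compound 2 (`COc1cc(N2C(=O)[C@@H](Oc3ccccc3)[C@H]2c2ccc(N(C)C)cc2)cc(OC)c1OC`) gives 31000 nM
- compound 3 (`COc1cc(N2C(=O)[C@@H](Oc3ccccc3)[C@H]2c2ccc3ccccc3c2)cc(OC)c1OC`) gives 282000 nM

Compound 2 sits level with compound 1, as shown by a 1.2-fold higher number from compound 1 to compound 2 (0.08 log units; within the scatter) and stands well apart from the highest number, as shown by a 9.1-fold higher number from compound 2 to compound 3 (0.96 log units; beyond the scatter) in this series.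

Compound 4 (`CCOC(=O)/C=C/c1ccc([C@@H]2[C@H](Oc3ccccc3)C(=O)N2c2cc(OC)c(OC)c(OC)c2)cc1`) carries one change from compound 2: 2-(ethoxycarbonyl)ethenyl in place of dimethylamino on an aromatic carbon with 2-(ethoxycarbonyl)ethenyl in place of dimethylamino on an aromatic carbon, para to a large group. Within the data shown here, no measured step makes this exact change. The closest evidence comes from changes of the whole group on the saturated ring carbon. Compound 3 shows a large shift in an 11-fold higher number from compound 1 to compound 3 (1.04 log units; beyond the scatter) and a modest one in a 9.1-fold higher number from compound 2 to compound 3 (0.96 log units; beyond the scatter) but both replace the entire phenyl-bearing group. Compound 2 shows in a 1.2-fold higher number from compound 1 to compound 2 (0.08 log units; within the scatter) that a substituent swap on the phenyl can leave the number unmoved.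

A small rise is therefore expected, not beyond the scatter, and the estimated step is a 1.6-fold higher number from compound 2 to compound 4 (0.21 log units; within the scatter) in this assay with real uncertainty upward. For compound 4 the expected value is 50000 nM with an estimated range from 12000 nM to 250000 nM in this assay for now.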

Compound 4, half-maximal inhibitory concentration: 87000 nM
Compound 4: the middle estimate sits 1.7-fold (0.24 log units) below what was measured; measured number inside the range.
By their numbers in this assay, from the lowest: compounds 1 and 2 (each within the scatter of the next); then compound 4; then compound 3.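

In this assay, a change confined to the aromatic carbon para to a large group moves the number beyond the scatter: 2-(ethoxycarbonyl)ethenyl in place of dimethylamino gives a 2.8-fold higher number from compound 2 to compound 4 (0.45 log units; beyond the scatter). Among these compounds, the earlier substituent swap on this phenyl, a 1.2-fold higher number from compound 1 to compound 2 (0.08 log units; within the scatter), stayed within the scatter, so this step is the first to show that the phenyl's substituents are not all interchangeable here, even with the group on the saturated ring carbon still a substituted phenyl. Nothing measured here explains this rise in the number.

The compounds shown leave open whether the step follows from the ester, the double bond or the whole of the new group. A carboxylic acid or a saturated propanoate ester chain at this position would begin to separate these parts.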